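A few compounds are considered here, and "the series" means these few. Any claim that something is new, unique, unknown or untested is made for them only; others in the source may bear on it.

Compound 1 `CCCC(=O)Nc1cc(Oc2ccc(Nc3nccc4[nH]cc(-c5ccc(F)cc5)c(=O)c34)cc2F)ccn1` carries a propylcarbonyl amide on its shared core. In a functional assay on MKN-45 cells (Homo sapiens) for antiproliferative activity, read by MTT assay, with a stated time of 72 h, tested at 10 uM (a lower number here means less inhibition, a higher number more inhibition at the concentration tested (going by the name of the read-out)), compound 1 gives 64.6%. Two close relatives have been measured in the same way: compound 2 `CC(C)(C)C(=O)Nc1cc(Oc2ccc(Nc3nccc4[nH]cc(-c5ccc(F)cc5)c(=O)c34)cc2F)ccn1` gives 62.5%, and compound 3 `O=C(CO)Nc1cc(Oc2ccc(Nc3nccc4[nH]cc(-c5ccc(F)cc5)c(=O)c34)cc2F)ccn1` gives 63%. Numerically compound 1 stands at the top of the three, but the step of a number 2.1 percentage points lower from compound 1 to compound 2 (within the scatter) and the step of a number 1.6 percentage points lower from compound 1 to compound 3 (within the scatter) both lie within the usual scatter, as does the step of a number 0.5 percentage points higher from compound 2 to compound 3 (within the scatter), so the three compounds cannot be told apart on these numbers.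

Compound 4 `O=C(Nc1cc(Oc2ccc(Nc3nccc4[nH]cc(-c5ccc(F)cc5)c(=O)c34)cc2F)ccn1)C1CCC1` differs from compound 1 in one place: cyclobutyl in place of propyl on a carbonyl carbon. Among the compounds with values here, the steps that bear on this are the ones that also exchange the group on the carbonyl carbon of the amide, namely a number 2.1 percentage points lower from compound 1 to compound 2 (within the scatter), where tert-butyl replaces propyl, and a number 1.6 percentage points lower from compound 1 to compound 3 (within the scatter), where hydroxymethyl replaces propyl. Neither moved the read-out beyond the scatter, although the groups introduced there are quite unlike one another. A cyclobutyl in place of propyl on a carbonyl carbon is therefore expected to leave the read-out essentially where compound 1 stands, with a step of a number 1.6 percentage points lower from compound 1 to compound 4 (within the scatter) expected, which is none beyond the scatter. Compound 4 is accordingly estimated to give 63%, with an expected range from 52% to 74%.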

Compound 4, a percentage reported as inhibition, at one concentration (the size of the read-out at that concentration, not a potency): 52.8%
Compound 4: the middle estimate sits 10.2 percentage points above what was measured; the range from low to high includes it.
By their numbers in this assay, from the lowest: compounds 4, 2, 3 and 1 (each within the scatter of the next, the first and the last beyond it).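

Within the data shown here, the carbonyl position is not indifferent to the group it carries: in this assay, the exchange for cyclobutyl gives a number 11.8 percentage points lower from compound 1 to compound 4 (beyond the scatter) and a number 10.2 percentage points lower from compound 3 to compound 4 (beyond the scatter), the first steps at this position to pass beyond the scatter, whereas propyl, tert-butyl and hydroxymethyl could not be told apart. The change is not clear-cut against every earlier group, however, since a number 9.7 percentage points lower from compound 2 to compound 4 (within the scatter) leaves compound 4 and the tert-butyl amide inseparable, so the loss is established only against the propyl and hydroxymethyl amides. Nothing available explains why this exchange of an open propyl chain for a four-membered carbon ring should lower the read-out.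

The compounds shown leave open whether the loss belongs to the four-membered ring in particular or would also appear with a cyclopropyl or cyclopentyl group on the carbonyl carbon. They also leave open how a longer chain such as hexyl, or a chain ending in an amine or a carboxylic acid, would read at this position in this assay.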